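Small azetidine amide changes and kinetic solubility

The compounds below may be only part of what the source reports. "The series", "measured", "known", "first", "only" and "open" are said of these compounds alone.

Measured so far in a physicochemical assay for solubility, measured as kinetic solubility (on this read-out lower numbers stand for lower solubility and higher numbers for higher solubility), are these compounds:
Compound 1 `Cc1cnc(NC(=O)c2cc(Oc3ccc(C#N)cc3)c3cc(C)oc3c2)cn1` gives 2000 nM
Compound 2 `Cc1cc2c(Oc3cnc(C(=O)N4CC(C)C4)cn3)cc(C(=O)Nc3cnccn3)cc2o1` gives 49000 nM
Compound 3 `Cc1cc2c(Oc3cnc(C(=O)N4CC(C)(C)C4)cn3)cc(C(=O)Nc3cnccn3)cc2o1` gives 78000 nM

Compound 3 (78000 nM) lies within the scatter of compound 2 (49000 nM), while compound 1 (2000 nM) sits far lower, beyond the scatter.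

Compound 4 `COC1CN(C(=O)c2cnc(Oc3cc(C(=O)Nc4cnccn4)cc4oc(C)cc34)cn2)C1` has not yet been measured. It differs from compound 3 in one place (3-methoxyazetidin-1-yl in place of 3,3-dimethylazetidin-1-yl on a carbonyl carbon), with 3-methoxyazetidin-1-yl in place of 3,3-dimethylazetidin-1-yl on a carbonyl carbon.

Going by the values given here, the one measured step on that saturated ring is a 1.6-fold higher number from compound 2 to compound 3 (0.20 log units; within the scatter) and it lies within the scatter. Among the compounds with values here, no measured compound carries 3-methoxyazetidin-1-yl, so this support is thin. In this assay no step beyond the scatter is expected, and the estimated change is a 1.1-fold higher number from compound 3 to compound 4 (0.04 log units; within the scatter) in size. For compound 4 the expected value is 85000 nM with an estimated range (38000 nM to 170000 nM).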

Compound 4, solubility: 158000 nM
Compound 4: the middle estimate sits 1.9-fold (0.27 log units) below what was measured; low and high end bracket the measured number.
By their numbers in this assay, from the lowest: compound 1; then compounds 2 and 3 (each within the scatter of the next); then compound 4.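

In this assay, this position on the carbonyl carbon now shows a step beyond the scatter: 3-methoxyazetidin-1-yl in place of 3,3-dimethylazetidin-1-yl gives a 2.0-fold higher number from compound 3 to compound 4 (0.31 log units; beyond the scatter). Methoxy in place of methyl on the saturated ring carbon gives a 3.2-fold higher number from compound 2 to compound 4 (0.51 log units; beyond the scatter), whereas the only earlier step on this ring, a 1.6-fold higher number from compound 2 to compound 3 (0.20 log units; within the scatter), stayed within the scatter. Both new steps are modest, and the entering group has the same count of heavy atoms as the group it replaces but swaps a carbon for an oxygen and carries one hydrogen-bond acceptor.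

Nothing shown here gives a measured reason for the higher numbers. Going by these compounds, whether the rise is particular to methoxy remains open, as a hydroxyl, an amine or a longer ether chain on the same saturated ring carbon could give a different number.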